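Series notes: from compound 1 to compound 4

A few compounds are considered here, and "the series" means these few. Any claim that something is new, unique, unknown or untested is made for them only; others in the source may bear on it.

Measured in an assay on CHO cells for displacement of a labelled ligand from prostaglandin E2 receptor EP1 subtype (Homo sapiens); a higher number here means a weaker inhibitor, a lower number a stronger inhibitor:
compound 1 `CCc1ccccc1N(Cc1nnc(Cc2ccccc2)o1)S(=O)(=O)c1ccc(C)cc1`: 1000 nM
compound 2 `Cc1ccc(S(=O)(=O)N(Cc2nnc(Cc3ccc(Cl)cc3Cl)o2)c2cccc(Cl)c2C)cc1`: 63.1 nM
compound 3 `CCOc1ccc(Cc2nnc(CN(c3cccc(Cl)c3Cl)S(=O)(=O)c3ccc(C(F)(F)F)cc3)o2)cc1`: 2.51 nM

Compound 1 stands at the highest number of the three, beyond the scatter from compound 2 and further still from compound 3. Compound 4 `CCc1ccccc1N(Cc1nnc(COc2ccc(OC)cc2)o1)S(=O)(=O)c1ccc(C)cc1` is compound 1 with 4-methoxyphenoxy in place of phenyl on a saturated chain carbon bound to an aromatic carbon. Among the compounds with values here, no single-change pair among the measured compounds covers this exchange; compounds 2 and 3 differ from compound 1 in several places at once, so their values cannot be read as the effect of this change alone. For compound 4 a modest downward step is expected in this assay, a 1.7-fold lower number from compound 1 to compound 4 (0.22 log units; within the scatter), possibly still within the scatter. Compound 4 is estimated at 600 nM, with a range of 150 nM to 2500 nM.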

Compound 4, half-maximal inhibitory concentration: 25.1 nM
Compound 4: the middle estimate sits 24-fold (1.38 log units) above what was measured; measured number outside the range, below it.
By their numbers in this assay, from the lowest: compound 3; then compound 4; then compound 2; then compound 1.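

In this assay, 4-methoxyphenoxy in place of phenyl on a saturated chain carbon bound to an aromatic carbon gives a 40-fold lower number from compound 1 to compound 4 (1.60 log units; beyond the scatter). This position therefore responds strongly to the group it carries, and the larger group, with two hydrogen-bond acceptors where phenyl has none, goes with the lower number. Nothing measured here accounts for the size of this step.

As far as these compounds go, the ether oxygen and the methoxy enter together, so their separate shares remain open. Plain phenoxy or 4-methoxyphenyl at this place would separate them.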